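Trading Two Methyl Groups for One Trifluoromethyl Group

The source may hold more compounds than are shown below. What is called first, only, known or untested is meant among the compounds shown, and "the series" means these compounds.

Of the compounds shown here, three have been measured in a functional assay on HL-60 cells (Homo sapiens) for inhibition, read by MTT assay, with a stated time of 72 h; on this read-out lower numbers stand for stronger inhibition and higher numbers for weaker inhibition. Compound 1 `CC(=O)Nc1cccc(-c2nc(C)oc2C(=O)N2CCN(c3cccc(Cl)c3)CC2)c1` gives 208 nM, compound 3 `COc1cc(OC)cc(N2CCN(C(=O)c3onc(C)c3-c3ccccc3)CC2)c1` gives 152 nM, and compound 2 `Cc1nc(-c2ccccc2)c(C(=O)N2CCN(c3cccc(C)c3C)CC2)o1` gives 35 nM. Compound 2 thus has the lowest number of the three, and its gaps to compound 3 and to compound 1 both lie beyond the usual scatter, so it is the most potent of the compounds measured here. Compound 4 `Cc1nc(-c2ccccc2)c(C(=O)N2CCN(c3cccc(C(F)(F)F)c3)CC2)o1` has not yet been measured. It differs from compound 2 in one place: 3-(trifluoromethyl)phenyl in place of 2,3-dimethylphenyl on an amine nitrogen in a ring. Among the compounds with values here, no measured pair isolates this change, so the size of the step in this assay is uncertain; a small loss seems most likely, possibly within the scatter. Compound 4 is therefore estimated at 70 nM, with a range from 25 nM to 250 nM, because compound 2 at 35 nM is the nearest measured anchor. The expected step is a 2.0-fold higher number from compound 2 to compound 4 (0.30 log units; within the scatter).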

Compound 4, half-maximal inhibitory concentration: 153 nM
The estimate for compound 4 lay 2.2-fold (0.34 log units) below the measured number; low and high end bracket the measured number.
By their numbers in this assay, from the lowest: compound 2; then compounds 3, 4 and 1 (each within the scatter of the next).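

The exchange of 2,3-dimethylphenyl for 3-(trifluoromethyl)phenyl gives a 4.4-fold higher number from compound 2 to compound 4 (0.64 log units; beyond the scatter) in this assay on an otherwise unchanged structure. This first single-change pair shows that the group on this ring nitrogen affects potency, and that this exchange weakens it beyond the scatter. Nothing available explains the size of this step.

From the compounds shown here alone, it remains open whether the loss comes from dropping a methyl group or from introducing trifluoromethyl. A 3-methylphenyl group on the same core would help separate these two parts of the change.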